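Trifluoromethyl in place of fluoro on compound 2

This account rests on a few compounds, and the source may have more. Where it says the series, first, only, none or still open, it means among the compounds named here.

Values in a functional assay on SMMC-7721 cells (Homo sapiens) for cytotoxicity, read by MTT assay, with a stated time of 24 h (on this read-out lower numbers stand for stronger inhibition and higher numbers for weaker inhibition), so far
- Compound 1 `CN1C/C(=C\c2cccnc2)C(=O)/C(=C/c2ccccc2C(F)(F)F)C1` gives 3900 nM
- Compound 2 `O=C1/C(=C/c2cccnc2)CNC/C1=C\c1ccccc1F` gives > 20000 nM
- Compound 3 `O=C1/C(=C/c2cccnc2)CN(S(=O)(=O)c2ccccc2)C/C1=C\c1ccccc1F` gives 19100 nM
- Compound 4 `O=C1/C(=C/c2cccnc2)CNC/C1=C\c1ccccc1C(F)(F)F` has no value yet

Compound 2 is recorded at > 20000 nM as a limit and not a number.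

Compound 4 differs from it in one place, on an aromatic carbon of a six-membered aromatic ring of carbon only, ortho to a large group, where trifluoromethyl replaces fluoro trifluoromethyl in place of fluoro on an aromatic carbon and the rest stays the same.

Among the measured compounds shown here, the only measured step is an at least 1.0-fold lower number from compound 2 to compound 3 (0.01 log units; that floor lies within the scatter) for phenylsulfonyl in place of hydrogen on an amine nitrogen in a ring, which is a change at another place. For the measured compounds named here, no measured pair isolates the exchange itself.

Compound 1 also carries trifluoromethyl, with methyl on that nitrogen, and gives 3900 nM in this assay while compound 3, with fluoro, gives 19100 nM on the same read-out.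

On the value of compound 1 at 3900 nM a move toward lower numbers is expected, estimated as an at least 2.0-fold lower number from compound 2 to compound 4 (0.30 log units; that floor lies within the scatter) with much uncertainty.

In this assay compound 4 is estimated at 10000 nM (expected range 4000 nM to 20000 nM).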

Compound 4, half-maximal inhibitory concentration: 5100 nM
The estimate for compound 4 lay 2.0-fold (0.29 log units) above the measured number, and the stated range covers the measured number.
By their numbers in this assay, from the lowest: compounds 1 and 4 (each within the scatter of the next); then compound 3. At a limit, above all of these: compound 2.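

In this assay, trifluoromethyl in place of fluoro on an aromatic carbon, ortho to a large group, gives an at least 3.9-fold lower number from compound 2 to compound 4 (0.59 log units; beyond the scatter), so this exchange is now isolated in a single measured pair and the step lies beyond the scatter. Compound 2 stands at a limit and not at a number, so the size of this step is only a floor, because the comparison starts from that limit: the limit of > 20000 nM in this assay, at which 1 of the 4 values shown sits.
With trifluoromethyl at this position, hydrogen in place of methyl on the amine nitrogen in the ring gives a 1.3-fold higher number from compound 1 to compound 4 (0.12 log units; within the scatter), so this change at the nitrogen shows no step beyond the scatter.

From the compounds shown here alone, whether the exchange of fluoro for trifluoromethyl gives a similar step with methyl or phenylsulfonyl on the nitrogen stays open. Going by these compounds, what a methoxy group, a nitrile or an amine on this aromatic carbon would give also stays open.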